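Swapping a thioester for a propyl ketone on a diene chain

The source may report more compounds than this note shows. Statements on the series, on what has been measured and on what is new or still open speak of the compounds shown alone.

Measured so far in a physicochemical assay for lipophilicity; a higher number here means a more lipophilic compound, a lower number a more polar compound:
compound 1, `COC(=O)/C=C(C)/C=C/CC(C)CCCC(C)C`, 6.2
compound 2, `CC(/C=C/CC(C)CCCC(C)C)=C\C(=O)OC(C)(C)C`, 7.56
compound 3, `CC(/C=C/CC(C)CCCC(C)C)=C\C(=O)SC(C)C`, 8.39

Compound 3 stands highest of the three: a number 0.83 log units higher from compound 2 to compound 3 (beyond the scatter) and a number 2.19 log units higher from compound 1 to compound 3 (beyond the scatter) both point up to it. Compound 4 is `CCCC(=O)/C=C(C)/C=C/CC(C)CCCC(C)C`, and it differs from compound 3 by propyl in place of isopropylsulfanyl on a carbonyl carbon. Within the data shown here, both measured steps that bear on this place put isopropylsulfanyl in, and both raised the number; no measured step takes it out again for a plain chain, so the size of the reverse step is uncertain. Compound 4 is expected to come out lower, with a step of a number 0.99 log units lower from compound 3 to compound 4 (beyond the scatter). Compound 4 is estimated at 7.4, within 6.6 to 8.2.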

Compound 4, partition coefficient: 6.81
The estimate for compound 4 lay 0.59 log units above the measured number; low and high end bracket the measured number.
By their numbers in this assay, from the lowest: compound 1; then compound 4; then compound 2; then compound 3.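

Propyl on a carbonyl carbon places compound 4 inside the range set by the earlier compounds in this assay, not at either end: the step away from isopropylsulfanyl gives a number 1.58 log units lower from compound 3 to compound 4 (beyond the scatter), and the step away from tert-butoxy gives a number 0.75 log units lower from compound 2 to compound 4 (beyond the scatter), while the step away from methoxy gives a number 0.61 log units higher from compound 1 to compound 4 (beyond the scatter). So a carbonyl carbon carrying plain carbon and no sulfur or oxygen still stands above the methoxy compound. No measured evidence here explains this order. Where a longer chain or an amine on the same carbonyl carbon would fall remains open.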